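The source may hold more compounds than are shown below. What is called first, only, known or untested is meant among the compounds shown, and "the series" means these compounds.

Compound 1, `COc1ccc(-c2cc(=O)n(CC(C)C)nc2-c2ccc(OC)cc2)cc1`: in a functional assay on HL-60 cells (Homo sapiens) for inhibition (on this read-out higher numbers stand for weaker inhibition and lower numbers for stronger inhibition), compound 1 gives only a limit, > 100000 nM.
Compound 2, `COc1ccc(-c2cc(=O)n(C)nc2-c2ccc(OC)cc2)cc1`: in this assay compound 2 gives 1130 nM.
Compound 3, `COc1ccc(-c2cc(=O)n(C3CCCC3)nc2-c2ccc(OC)cc2)cc1`: in this assay compound 3 gives 510 nM.

Of the two numbers shown, compound 3 stands lowest; its nearest neighbour is compound 2, and the step of a 2.2-fold lower number from compound 2 to compound 3 (0.35 log units; beyond the scatter) lies beyond the scatter. The account now follows the step to compound 4, `COc1ccc(-c2cc(=O)n(C3CC3)nc2-c2ccc(OC)cc2)cc1`, which differs from compound 3 in one place: cyclopropyl in place of cyclopentyl on an aromatic nitrogen. Two measured steps end at compound 3 and bear on this change. The step of an at least 190-fold lower number from compound 1 to compound 3 (2.29 log units; beyond the scatter) is large. For compound 1, however, only a limit is known, (the limit of > 100000 nM in this assay, at which 1 of the 3 values shown sits). The step of a 2.2-fold lower number from compound 2 to compound 3 (0.35 log units; beyond the scatter) is modest. Cyclopropyl keeps a non-aromatic ring of carbon only on the aromatic nitrogen, as cyclopentyl does, but a smaller one, so the change sits between the two groups compared in that modest step. The step of a 1.6-fold higher number from compound 3 to compound 4 (0.20 log units; within the scatter) is therefore expected to be small, a slight rise in the number at most, possibly within the scatter. Compound 4 is estimated at 800 nM, within 350 nM to 1800 nM.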

Compound 4, half-maximal inhibitory concentration: 7980 nM
Compound 4: the middle estimate sits 10-fold (1.00 log units) below what was measured, outside the stated range (above it).
By their numbers in this assay, from the lowest: compound 3; then compound 2; then compound 4. At a limit, above all of these: compound 1.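

Ring size on the aromatic nitrogen matters strongly here: a carbon-only ring is not enough to hold the number low, since the step is a 16-fold higher number from compound 3 to compound 4 (1.19 log units; beyond the scatter). The number also does not follow group size in step with the count of heavy atoms, and compound 2, with its methyl, goes against any such trend, as the step is a 7.1-fold higher number from compound 2 to compound 4 (0.85 log units; beyond the scatter). Compound 1 gives only a limit, so the step of an at least 12-fold lower number from compound 1 to compound 4 (1.09 log units; beyond the scatter) fixes a bound and no exact size, leaving isobutyl at the top of the order only as a limit: the limit of > 100000 nM in this assay, at which 1 of the 4 values shown sits.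

The compounds shown leave open how the number moves with cyclobutyl or cyclohexyl on the aromatic nitrogen, which would show whether cyclopropyl stands alone or marks a trend among rings. They also leave open what a longer straight chain or an amine at this position would give.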